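The source may report more compounds than this note shows. Statements on the series, on what has been measured and on what is new or still open speak of the compounds shown alone.

Three ureas share one core and differ only on the aryl ring: compound 2 `Cc1cc(NC(=O)Nc2ccc(F)cc2)c2ccccc2n1`, compound 1 `Cc1cc(NC(=O)Nc2ccc(F)c(F)c2)c2ccccc2n1` and compound 3 `Cc1cc(NC(=O)Nc2ccccc2F)c2ccccc2n1`. In a physicochemical assay for solubility, at pH 7.4 (a lower number here means a less soluble compound, a higher number a more soluble compound), compound 2 gives 3700 nM, compound 1 gives 500 nM and compound 3 gives 3800 nM. The step of a 7.4-fold lower number from compound 2 to compound 1 (0.87 log units; beyond the scatter) comes from fluoro in place of hydrogen on an aromatic carbon. The two cores differ by 2-fluorophenyl in place of 4-fluorophenyl on an amide-type nitrogen, and the step of a 1.0-fold higher number from compound 2 to compound 3 (0.01 log units; within the scatter) lies within the scatter, so nothing is made of that pair's order. Compound 4 `Cc1cc(NC(=O)Nc2cc(F)ccc2F)c2ccccc2n1` is not yet measured in this assay; it arises from compound 3 by fluoro in place of hydrogen on an aromatic carbon, the same kind of change as that from compound 2 to compound 1, though the entering fluoro sits para to a fluoro group rather than ortho to one. Because compound 1 fell by a 7.4-fold lower number from compound 2 to compound 1 (0.87 log units; beyond the scatter), compound 4 is expected to show a lower number than compound 3, estimated as a step of a 4.8-fold lower number from compound 3 to compound 4 (0.68 log units; beyond the scatter). Compound 4 is therefore estimated at 800 nM, between 300 nM and 2500 nM.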

Compound 4, solubility: 500 nM
Compound 4: middle estimate off by 1.6-fold (0.20 log units), on the high side, within the range that was stated.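

The same change, carried to a second core, brings a 7.6-fold lower number from compound 3 to compound 4 (0.88 log units; beyond the scatter) in this assay, matching the direction and coming close to the size of a 7.4-fold lower number from compound 2 to compound 1 (0.87 log units; beyond the scatter), even though the entering fluoro now sits para to a fluoro group. Across these two pairs the change therefore carried over, and neither pair goes against that, but two pairs show only these two placements on these two cores. Nothing shown explains the fall in either pair.

The compounds shown leave open whether a chloro or a methoxy group entering at the same place would give a similar step. They also leave open whether the fluoro step would hold on a core bearing an amine or a carboxylic acid.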